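Amide variation on the shared core, cellular inhibition

The source may hold more compounds than are shown below. What is called first, only, known or untested is meant among the compounds shown, and "the series" means these compounds.

Compound 2 `CCN(CC)S(=O)(=O)c1ccc(S(=O)(=O)N2CCC[C@@H](C(=O)N3CCOCC3)C2)cc1` carries a morpholin-4-yl group on the carbonyl carbon. In a functional assay on BXPC-3 cells (Homo sapiens) for inhibition, read by MTT assay, with a stated time of 7 days (on this read-out higher numbers stand for weaker inhibition and lower numbers for stronger inhibition), compound 2 gives 790 nM, the lowest of the two numbers shown. Compound 1 `CCN(CC)S(=O)(=O)c1ccc(S(=O)(=O)N2CCC[C@@H](C(=O)N3CCC(O)CC3)C2)cc1` gives 4710 nM in this assay. Among the measured compounds shown here, the only measured step is a 6.0-fold lower number from compound 1 to compound 2 (0.78 log units; beyond the scatter), which sits at the same carbonyl carbon. Compound 3 `CCN(CC)S(=O)(=O)c1ccc(S(=O)(=O)N2CCC[C@@H](C(=O)NC3CCOCC3)C2)cc1` differs from compound 2 by (oxan-4-yl)amino in place of morpholin-4-yl on a carbonyl carbon. For the measured compounds named here, the measured step bears on this change only in that it shows the group on the carbonyl carbon can move the number beyond the scatter; no measured pair exchanges morpholin-4-yl for a group with 1 hydrogen-bond donor, so the direction for compound 3 is not fixed by the data. A modest rise in this assay, or no change beyond the scatter, is expected for compound 3. For compound 3 the estimate is 1500 nM, with a range from 400 nM to 6000 nM. This estimate means an expected step of a 1.9-fold higher number from compound 2 to compound 3 (0.28 log units; within the scatter).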

Compound 3, half-maximal inhibitory concentration: 8570 nM
The estimate for compound 3 lay 5.7-fold (0.76 log units) below the measured number; measured number above the stated range.
By their numbers in this assay, from the lowest: compound 2; then compounds 1 and 3 (each within the scatter of the next).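

In this assay, among the compounds shown here, (oxan-4-yl)amino in place of morpholin-4-yl on the carbonyl carbon gives an 11-fold higher number from compound 2 to compound 3 (1.04 log units; beyond the scatter) and is the first exchange here to show how much this position can cost. Compound 2 now stands apart from both other amides, while a 1.8-fold higher number from compound 1 to compound 3 (0.26 log units; within the scatter) leaves those two amides without a reliable order, so among these three compounds only morpholin-4-yl gives the low number. Nothing available here accounts for the step from compound 2 to compound 3.

Still open, from the compounds shown here alone, is whether the low number of compound 2 holds with a piperidin-1-yl or 4-methylpiperazin-1-yl group on the carbonyl carbon. A (methyl)(oxan-4-yl)amino group would also separate the loss of the amide hydrogen from the change of ring.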